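Ring enlargement on the ether arm of compound 3

This account rests on a few compounds, and the source may have more. Where it says the series, first, only, none or still open, it means among the compounds named here.

In an assay on HEK cells for antagonist activity at transient receptor potential cation channel subfamily V member 1 (Homo sapiens), read by FLIPR (on this read-out higher numbers stand for weaker inhibition and lower numbers for stronger inhibition), compound 1 `CCCN(CCC)c1nc(C(F)(F)F)ccc1CNC(=O)Nc1cccc2[nH]c(=O)ccc12` gives 5.21 nM, compound 2 `CCCCCOc1nc(C(F)(F)F)ccc1CNC(=O)Nc1cccc2[nH]c(=O)ccc12` gives 2.72 nM and compound 3 `O=C(NCc1ccc(C(F)(F)F)nc1OCC1CCC1)Nc1cccc2[nH]c(=O)ccc12` gives 1.49 nM, the lowest of the three numbers, though its gap to compound 2 is within the scatter. Compound 4 `O=C(NCc1ccc(C(F)(F)F)nc1OCC1CCCC1)Nc1cccc2[nH]c(=O)ccc12` carries cyclopentyl in place of cyclobutyl on a saturated chain carbon bound to an oxygen on an aromatic ring. The step closest in kind is a 1.8-fold lower number from compound 2 to compound 3 (0.26 log units; within the scatter), which lies within the scatter; a 3.5-fold lower number from compound 1 to compound 3 (0.54 log units; beyond the scatter) is modest but concerns a different group at the aromatic carbon. Nothing shown suggests that exchanging one small ring for another at this position moves the number, so no step beyond the scatter is expected in this assay. Compound 4 is therefore estimated at 1.3 nM (range 0.6 nM to 3 nM), an expected step of a 1.1-fold lower number from compound 3 to compound 4 (0.06 log units; within the scatter).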

Compound 4, half-maximal inhibitory concentration: 2.18 nM
Compound 4: middle estimate off by 1.7-fold (0.22 log units), on the low side; the range from low to high includes it.
By their numbers in this assay, from the lowest: compounds 3, 4, 2 and 1 (each within the scatter of the next, the first and the last beyond it).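

In this assay, the larger ring leaves the number within the scatter, with a 1.5-fold higher number from compound 3 to compound 4 (0.17 log units; within the scatter) and, against the open chain, a 1.2-fold lower number from compound 2 to compound 4 (0.10 log units; within the scatter). Against dipropylamino, cyclopentylmethoxy still gives a modest step beyond the scatter, a 2.4-fold lower number from compound 1 to compound 4 (0.38 log units; beyond the scatter), as cyclobutylmethoxy does, whereas the pentyloxy of compound 2 stays within it. Nothing available explains these numbers.

Still open, as far as these compounds go, is whether a cyclohexyl ring on the same saturated chain carbon would stay within the scatter. A tetrahydropyranyl ring or a hydroxyl group on the ring is equally untested here.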